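The source may report more compounds than this note shows. Statements on the series, on what has been measured and on what is new or still open speak of the compounds shown alone.

Measured so far:
compound 1, `COc1cc(C)cc(-c2c(-c3ccnc(-c4ccc(C(C)=O)cc4)c3)cnn2CC#N)c1` — > 100000 nM
compound 2, `COc1cc(C)cc(-c2nn(CC#N)cc2-c2ccnc(-c3ccc(N(C)C)cc3)c2)c1` — 1620 nM

Compound 1 stands only at a limit of the assay, not at a number: in a functional assay on KM12 cells (Homo sapiens) for inhibition, read by sulforhodamine B assay, with a stated time of 48 h (on this read-out higher numbers stand for weaker inhibition of growth and lower numbers for stronger inhibition of growth), compound 1 gives > 100000 nM. That reading sits at the limit of > 100000 nM in this assay, at which 1 of the 2 values shown sits. Among the measured compounds shown here, compound 2 differs from compound 1 in more than one place and so forms no single step with it; in this assay compound 2 gives 1620 nM.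

Compound 3, `COc1cc(C)cc(-c2c(-c3ccnc(-c4ccc(N(C)C)cc4)c3)cnn2CC#N)c1`, awaits measurement. It differs from compound 1 in one place: dimethylamino in place of acetyl on an aromatic carbon. For the measured compounds named here, no measured pair isolates this change. The step from compound 1 to compound 3 is expected to be a gain well beyond the scatter, an at least 20-fold lower number from compound 1 to compound 3 (1.30 log units; beyond the scatter), because compound 2 with the same dimethylamino group gives 1620 nM. Compound 3 is therefore estimated at 5000 nM, expected to fall between 1000 nM and 50000 nM.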

Compound 3, concentration for total growth inhibition: 264 nM
Beside the measured number, compound 3's estimate is 19-fold (1.28 log units) above it; the whole stated range lies above it.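

In this assay, swapping acetyl for dimethylamino on an aromatic carbon, para to a large group, gives an at least 370-fold lower number from compound 1 to compound 3 (2.57 log units; beyond the scatter). This position is therefore far from indifferent to what sits on it, even though the two groups match in heavy-atom count and in hydrogen-bond acceptor count, so those counts alone do not separate them. The reading for compound 1 is a limit of the assay, and the step is a minimum rather than an exact size because of that limit: the limit of > 100000 nM in this assay, at which 1 of the 3 values shown sits.

Among the compounds shown here, with only two groups compared at this position, it stays open whether a primary amine, a methoxy group or a morpholine ring would behave like dimethylamino or like acetyl. Also open, going by these compounds, is whether acetyl would weaken the core of compound 2 to the same degree.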